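A few compounds are considered here, and "the series" means these few. Any claim that something is new, unique, unknown or untested is made for them only; others in the source may bear on it.

Three compounds share one core and differ only in the aromatic ring attached at a single position. Compound 1 `O=Cc1ccc(-c2cn3ccnc3c(-c3ccc4ncn(C5CCCCC5)c4c3)n2)cc1` carries a 4-formylphenyl group; in a physicochemical assay for lipophilicity, using the shake flask method, in phosphate buffer, measured as octanol-water partition, with a stated time of 85 min, at pH 7.4 (a higher number here means a more lipophilic compound, a lower number a more polar compound), compound 1 gives 1.5. Compound 2 `c1cn2cc(-c3ccsc3)nc(-c3ccc4ncn(C5CCCCC5)c4c3)c2n1` carries a thiophen-3-yl group instead, and in this assay compound 2 gives 1.81, which is a number 0.31 log units higher from compound 1 to compound 2 (beyond the scatter). Compound 3 `Cc1cccc(-c2cn3ccnc3c(-c3ccc4ncn(C5CCCCC5)c4c3)n2)c1` carries a 3-methylphenyl group, and in this assay compound 3 gives 1.87. That is a number 0.37 log units higher from compound 1 to compound 3 (beyond the scatter) and a number 0.06 log units higher from compound 2 to compound 3 (within the scatter). Compound 3 therefore shows the highest of the three numbers, although its gap to compound 2 is within the scatter and only its gap to compound 1 is beyond it.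

Compound 4 `Clc1ccc(-c2cn3ccnc3c(-c3ccc4ncn(C5CCCCC5)c4c3)n2)cc1` has not yet been measured. It differs from compound 3 in one place: 4-chlorophenyl in place of 3-methylphenyl on an aromatic carbon. The measured steps that bear on this change are the three exchanges of the ring at this same position, of which two were modest and one lay within the scatter. Among these compounds, swapping one ring for another moved the number only a little, so for compound 4 a small step is expected, a number 0.13 log units higher from compound 3 to compound 4 (within the scatter), quite possibly within the scatter. The estimate for compound 4 in this assay is 2, with a range from 1.6 to 2.4.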

Compound 4, partition coefficient: 1.51
Beside the measured number, compound 4's estimate is 0.49 log units above it; measured number below the stated range.
By their numbers in this assay, from the lowest: compounds 1, 4, 2 and 3 (each within the scatter of the next, the first and the last beyond it).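

In this assay there is a number 0.36 log units lower from compound 3 to compound 4 (beyond the scatter) when 4-chlorophenyl takes the place of 3-methylphenyl. Both rings have the same count of heavy atoms and neither has a hydrogen-bond donor or acceptor, so these counted features alone do not settle the number at this position. Compound 1 also no longer stands apart from every other compound: chloro in place of formyl gives a number 0.01 log units higher from compound 1 to compound 4 (within the scatter) and 4-chlorophenyl in place of thiophen-3-yl gives a number 0.30 log units lower from compound 2 to compound 4 (within the scatter), while no measurement at hand accounts for any of these differences.

Compound 3 and compound 4 differ both in the group on the phenyl ring and in its numbered place on that ring, so 3-chlorophenyl and 4-methylphenyl would be needed to separate the two changes. As far as these compounds go, it also remains open how far the number would move with a phenyl ring carrying an amine or a carboxylic acid, or with a longer chain at this position.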